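Trimming a Propyl Thioether Down to a Free Thiol

This account rests on a few compounds, and the source may have more. Where it says the series, first, only, none or still open, it means among the compounds named here.

Three related compounds share one core and differ only in the group attached to a sulfur on that core. Compound 1 `CC(=O)Nn1c(COc2ccccc2C2=NOC(c3ccc(Cl)cc3Cl)C2)nnc1Sc1ccccc1` and compound 2 `CC(=O)Nn1c(COc2ccccc2C2=NOC(c3ccc(Cl)cc3Cl)C2)nnc1SCC(C)C` were both included in the study, but in an ADME assay (MDM cells, Homo sapiens) for cytotoxicity, read by resazurin assay, with a stated time of 3 days (on this read-out lower numbers stand for stronger inhibition and higher numbers for weaker inhibition), compound 1 gives "not determined" (no result reported) and compound 2 gives "not determined" (no result reported), so neither has a recorded number. For the measured compounds named here, compound 3 `CCCSc1nnc(COc2ccccc2C2=NOC(c3ccc(Cl)cc3Cl)C2)n1NC(C)=O` is therefore the single point of reference: in this assay compound 3 gives 128 ug/mL, which is the only number available, so nothing can be said about how it compares with compound 1 or compound 2.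

The step to compound 4 `CC(=O)Nn1c(S)nnc1COc1ccccc1C1=NOC(c2ccc(Cl)cc2Cl)C1` is a small one on paper: hydrogen in place of propyl on a sulfur. Going by the values given here, since no pair of measured compounds shows a step of this kind, there is no measured precedent to lean on, and the expectation rests on the single value of compound 3 alone.

The expected step in this assay from compound 3 to compound 4 is no change at the digits printed from compound 3 to compound 4 (within the scatter), that is, no change beyond the usual scatter. On that basis compound 4 is expected to give about 128 ug/mL in this assay, with a plausible range from 50 ug/mL to 300 ug/mL.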

Compound 4, half-maximal inhibitory concentration: 1.3 ug/mL
Beside the measured number, compound 4's estimate is 98-fold (1.99 log units) above it; the measured number lies below the stated range.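

In this assay the change of propyl to hydrogen, on a sulfur whose other neighbour is an aromatic carbon, gives a 98-fold lower number from compound 3 to compound 4 (1.99 log units; beyond the scatter) and so marks this sulfur as a place where a small edit can move the number a long way. The earlier compounds shown here could not show this, since compound 1 and compound 2 carry other groups on the same sulfur but have no recorded number, and compound 3 on its own offered nothing to compare. The sensitivity therefore rests on this single pair, and no accompanying measurement explains the size of the step.

A methyl or an ethyl chain on the sulfur would help to show whether the number falls gradually as the chain shortens or only once the chain is gone altogether. An amine or a hydroxyl group in place of the sulfanyl group would help to show whether the sulfur itself is needed for so low a number, or whether other small groups at this place would give a similar result.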